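The source may report more compounds than this note shows. Statements on the series, on what has been measured and on what is new or still open speak of the compounds shown alone.

Of the compounds shown here, two with a shared core have been tested so far in an ADME assay on HEK293 cells (Homo sapiens) for cytotoxicity, with a stated time of 72 h; on this read-out higher numbers stand for an effect only at larger amounts of compound and lower numbers for an effect already at smaller amounts. Compound 1 `Cc1cc(NC(=O)Nc2ccc(C)c(Cl)c2)c2ccccc2n1` gives > 25000 nM, which is a limit of the assay and not a number. Compound 2 `Cc1cc(NC(=O)Nc2ccccc2OC(F)(F)F)c2ccccc2n1` gives > 25000 nM, which is also a limit and not a number. Compound 2 therefore has no exact position, and the whole picture so far is the limit of > 25000 nM in this assay, at which 2 of the 2 values shown sit.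

Compound 3 `Cc1cc(NC(=O)Nc2ccccc2N)c2ccccc2n1` keeps the core of compound 2 but has amino in place of trifluoromethoxy on an aromatic carbon, ortho to a large group: amino in place of trifluoromethoxy on an aromatic carbon. Among the compounds with values here, no measured pair yet shows what such a swap does in this assay. Because of the limit of > 25000 nM in this assay, at which 2 of the 2 values shown sit, shared by compound 1 and compound 2, the expected change is none beyond the scatter, or a small move towards lower numbers. The expected size of an at least 1.2-fold lower number from compound 2 to compound 3 (0.09 log units; that floor lies within the scatter) is therefore small. Compound 3 is estimated at 20000 nM, with an expected range of 6000 nM to 40000 nM.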

Compound 3, half-maximal effective concentration: > 25000 nM
Compound 3 gave a limit, no number (the forecaster's own chance of this, stated with the estimate: 65%); middle value at least 1.2-fold (0.09 log units) away from the limit.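

Compound 2 and compound 3 both give a limit and not a number, so no step can be read for amino in place of trifluoromethoxy: the limit of > 25000 nM in this assay, at which 3 of the 3 values shown sit.

The compounds shown leave open how far apart these three compounds truly lie, and whether any change to the shared core gives an exact number.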